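Fluoro to chloro in a two-compound antiproliferative series

A few compounds are considered here, and "the series" means these few. Any claim that something is new, unique, unknown or untested is made for them only; others in the source may bear on it.

Measured so far, in a functional assay on SW480 cells (Homo sapiens) for antiproliferative activity, read by MTT assay, with a stated time of 48 h; a higher number here means a weaker inhibitor, a lower number a stronger inhibitor:
compound 1 `CCCCCCCCC(CCO)n1cnc2c(Cl)nc(Cl)nc21`: 24000 nM
compound 2 `CCCCCCCCCC(CCO)n1cnc2c(Cl)nc(F)nc21`: 12500 nM

Only these two values are available, and they lie within the usual scatter of each other. Compound 2, at 12500 nM, therefore cannot be ranked apart from compound 1, at 24000 nM. Both sit at the weak end of what this assay can report as a number, and neither stands out.

The next compound to be tested is compound 3 `CCCCCCCCCC(CCO)n1cnc2c(Cl)nc(Cl)nc21`. It differs from compound 2 by one exchange: chloro in place of fluoro on an aromatic carbon. The exchange places chloro in place of fluoro on an aromatic carbon, between two ring nitrogen atoms, and the rest of the structure stays the same.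

Among the compounds with values here, no step between measured compounds shows what such an exchange does, so the expectation has little support. With no direction indicated, no step beyond the scatter is expected. The expected change is a 1.3-fold higher number from compound 2 to compound 3 (0.11 log units; within the scatter), which is small and within that scatter. For compound 3 the estimated value is 16000 nM, with an expected range of 8000 nM to 32000 nM.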

Compound 3, half-maximal inhibitory concentration: 36300 nM
Compound 3: the middle estimate sits 2.3-fold (0.36 log units) below what was measured; measured number above the stated range.
By their numbers in this assay, from the lowest: compounds 2, 1 and 3 (each within the scatter of the next, the first and the last beyond it).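

In this assay, within the data shown here, chloro in place of fluoro on the aromatic carbon between two ring nitrogen atoms gives the first step beyond the scatter, a modest one (a 2.9-fold higher number from compound 2 to compound 3 (0.46 log units; beyond the scatter)). This position therefore responds to the choice of halogen, with the fluoro compound carrying the lower number of the pair. Methyl in place of hydrogen on a saturated chain carbon, by contrast, gives a step that stays within the scatter (a 1.5-fold higher number from compound 1 to compound 3 (0.18 log units; within the scatter)), so this chain change cannot be read as having any effect, and only the halogen exchange registers among these compounds. No measurement at hand explains the size or direction of the halogen step.

The shown compounds cover only fluoro and chloro at this carbon, so it remains open whether a bromo group, a methoxy group or an amine there would extend the step or reverse it. Also open, going by these compounds, is whether the same exchange would give a comparable step at the other chloro group, or on a core carrying a longer chain.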